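A few compounds are considered here, and "the series" means these few. Any claim that something is new, unique, unknown or untested is made for them only; others in the source may bear on it.

Compound 2 `CC1=C(C(=O)SC(C)C)C(c2ccoc2)NC(=O)N1` and compound 1 `CC1=C(C(=O)NC(C)C)C(c2ccoc2)NC(=O)N1` are close relatives. In an assay on membranes from HeLa cells for displacement of a labelled ligand from adenosine receptor A3 (Homo sapiens), read by scintillation counting, with a stated time of 180 min, tested at 1 uM (on this read-out higher numbers stand for more inhibition at the one concentration tested (going by the name of the read-out) and lower numbers for less inhibition), compound 1 gives 3%, and in this assay compound 2 gives 3%, so compound 2 stands level with compound 1 at the digits shown; the step of no change at the digits printed from compound 1 to compound 2 (within the scatter) lies within the scatter.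

Compound 3 `CCC(C)OC(=O)C1=C(C)NC(=O)NC1c1ccoc1` carries a further change at the same place: sec-butoxy in place of isopropylsulfanyl on a carbonyl carbon. For the measured compounds named here, the only measured step that bears on it, no change at the digits printed from compound 1 to compound 2 (within the scatter), also swapped the group on that carbonyl carbon and moved the number by nothing that rises above the scatter. Nothing measured suggests that a further swap there should behave differently. The expected step is therefore a number 1 percentage points higher from compound 2 to compound 3 (within the scatter), no change beyond the scatter. Compound 3 is thus estimated to give 4% in this assay, with a likely range from -6% to 14%.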

Compound 3, a percentage reported as inhibition, at one concentration (the size of the read-out at that concentration, not a potency): 11%
Estimate against measurement, compound 3: 7 percentage points below; measured number inside the range.
By their numbers in this assay, from the lowest: compounds 1, 2 and 3 (each within the scatter of the next).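

In this assay, the group on this carbonyl carbon has now been changed a second time, and the result is again small: a number 8 percentage points higher from compound 2 to compound 3 (within the scatter), and a number 8 percentage points higher from compound 1 to compound 3 (within the scatter). Isopropylamino, isopropylsulfanyl and sec-butoxy therefore cannot be told apart at this position in this read-out, even though the step to sec-butoxy changes both the atom attached to the carbonyl carbon and the carbon chain. No supporting measurement is available to explain these numbers.

The compounds shown leave open whether any group at this place can move the number beyond the scatter, such as a benzyloxy group, a longer chain like hexyloxy, or a free carboxylic acid. They also leave open whether the atom attached to the carbonyl carbon and the chain have separate effects.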